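Swapping the aryl group on the triazole-bound methylene

A few compounds are considered here, and "the series" means these few. Any claim that something is new, unique, unknown or untested is made for them only; others in the source may bear on it.

Compound 2 `Cc1ccc(S(=O)(=O)N(Cc2cn(Cc3ccc(F)cc3F)nn2)Cc2cn(S(=O)(=O)c3ccc(C)cc3)c3ccccc23)cc1` stands highest of the two compounds measured in a functional assay on 3T3-L1 cells (Mus musculus) for inhibition, with a stated time of 20 min, tested at 20 uM (on this read-out higher numbers stand for more inhibition at the one concentration tested (going by the name of the read-out) and lower numbers for less inhibition), where compound 2 gives 12.3%. Its neighbour is compound 1 `Cc1ccc(S(=O)(=O)N(Cc2cn(Cc3ccccc3Cl)nn2)Cc2cn(S(=O)(=O)c3ccc(C)cc3)c3ccccc23)cc1`, which in this assay gives -4.8%; the step of a number 17.1 percentage points higher from compound 1 to compound 2 (beyond the scatter) lies beyond the scatter and shows that the aryl group at this position matters to the read-out.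

Compound 3 `COc1ccc(Cn2cc(CN(Cc3cn(S(=O)(=O)c4ccc(C)cc4)c4ccccc34)S(=O)(=O)c3ccc(C)cc3)nn2)c(OC)c1OC` has not yet been measured in this assay. It differs from compound 2 in one place: 2,3,4-trimethoxyphenyl in place of 2,4-difluorophenyl on a saturated chain carbon bound to an aromatic nitrogen. Going by the values given here, the only measured step that bears on this change is a number 17.1 percentage points higher from compound 1 to compound 2 (beyond the scatter), which shows that exchanging one aryl group for another on the saturated chain carbon bound to the aromatic nitrogen can move the read-out by a modest amount. Among the compounds with values here, that step, however, compares two halogenated phenyl rings, and no measured compound carries a methoxy-bearing ring, so the direction for compound 3 is not given by the data. The expected step is therefore a number 2.3 percentage points lower from compound 2 to compound 3 (within the scatter), close to no change beyond the scatter. Compound 3 is estimated to give 10% in this assay, within a range from -8% to 28%.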

Compound 3, a percentage reported as inhibition, at one concentration (the size of the read-out at that concentration, not a potency): -18%
For compound 3 the middle estimate is 28 percentage points above the measured one; measured number outside the range, below it.
By their numbers in this assay, from the lowest: compound 3; then compound 1; then compound 2.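

In this assay, the position on the saturated chain carbon bound to an aromatic nitrogen proved more sensitive than the two halogenated rings had suggested, with a number 30.3 percentage points lower from compound 2 to compound 3 (beyond the scatter) when 2,3,4-trimethoxyphenyl replaced 2,4-difluorophenyl. The same ring also gave a number 13.2 percentage points lower from compound 1 to compound 3 (beyond the scatter) in place of 2-chlorophenyl, so among these three compounds the 2,3,4-trimethoxyphenyl group sits lowest and the two halogen-bearing rings both sit above it. No measurement available here explains why this exchange lowers the read-out.

The three compounds do not separate the loss of the halogens from the arrival of the methoxy groups, since compound 3 changes both at once, and a phenyl ring bearing a single methoxy group could begin to tell these apart. They also leave open whether a ring carrying an amine or a carboxylic acid, or an unsubstituted phenyl ring, would fall within the span set by compound 2 and compound 3 or outside it.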